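The compounds below may be only part of what the source reports. "The series", "measured", "known", "first", "only" and "open" are said of these compounds alone.

Two compounds built on a shared core have so far been examined in an ADME assay on HEK293 cells (Homo sapiens) for cytotoxicity, read by ATP content, with a stated time of 6 h; on this read-out lower numbers stand for higher toxicity in this test and higher numbers for lower toxicity in this test. Compound 1, `CCCCNc1nc(N)nc2ccn(Cc3ncc(C)c(OC)c3C)c12`, gives > 24000 nM in this assay, which is a limit of the assay rather than a measured number. Compound 2, `CCC(O)CNc1nc(N)nc2ccn(Cc3ccccn3)c12`, likewise gives > 24000 nM in this assay, and this too is a limit. Compound 2 therefore cannot be placed above or below compound 1, because the limit of > 24000 nM in this assay, at which 2 of the 2 values shown sit, leaves both at the same edge of what the test can report. Compound 3, `Cc1cc(CNc2nc(N)nc3ccn(Cc4ccccn4)c23)no1`, has not yet been measured. It differs from compound 2 in one place: 5-methyl-1,2-oxazol-3-yl in place of 1-hydroxypropyl on a saturated chain carbon bound to a nitrogen on an aromatic ring. Within the data shown here, no step between measured compounds exists here, and the two values shown give no sign that either compound reaches a toxic concentration within the tested range. The change in this assay is therefore expected to be none beyond the usual scatter, with compound 3 expected to remain at the limit. The estimate for compound 3 in this assay is 30000 nM, with the range expected to run from 15000 nM to 60000 nM. This estimate corresponds to an expected step that the limit leaves unreadable from compound 2 to compound 3.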

Compound 3, half-maximal cytotoxic concentration: > 24000 nM
Compound 3: only a limit was reported; the forecaster's own chance of this, stated with the estimate: 80%; the middle value is on the limit's open side.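

In this assay, among these compounds, no step from compound 2 to compound 3 can be read, because both values are limits and not numbers: the limit of > 24000 nM in this assay, at which 3 of the 3 values shown sit. The compounds shown leave open at what concentration, if any, each would become toxic in this test, and whether 5-methyl-1,2-oxazol-3-yl in place of 1-hydroxypropyl changes that concentration.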